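The compounds below may be only part of what the source reports. "The series", "measured", "known", "first", "only" and "open" are said of these compounds alone.

Working notes on the series. Compound 1, `COC[C@H]1CN(c2ccc(CCCO)cc2)C(=O)O1`, is the reference point. Among the compounds with values here, in a physicochemical assay for lipophilicity (on this read-out lower numbers stand for lower lipophilicity and higher numbers for higher lipophilicity), compound 1 gives 1.27, the second highest of the three numbers measured so far. Compound 2, `COC[C@H]1CN(c2ccc(CCO)cc2)C(=O)O1`, gives 1.13 in this assay, a change of a number 0.14 log units lower from compound 1 to compound 2 (within the scatter). Compound 3, `COC[C@H]1CN(c2ccc(OCC[C@@H](C)O)cc2)C(=O)O1`, gives 1.71; relative to the other two the steps are a number 0.44 log units higher from compound 1 to compound 3 (beyond the scatter) and a number 0.58 log units higher from compound 2 to compound 3 (beyond the scatter). Compound 4, `COC[C@H]1CN(c2ccc(OCCCC(C)O)cc2)C(=O)O1`, differs from compound 1 by (4-hydroxypentyl)oxy in place of 3-hydroxypropyl on an aromatic carbon. The step from compound 1 to compound 3 is the one that bears on this, since the group entering compound 4 is the longer chain analogue of the group entering compound 3; a rise beyond the scatter, somewhat larger than that step, is expected. Compound 4 is therefore estimated at 2.05, with a range of 1.7 to 2.4. The expected step is a number 0.78 log units higher from compound 1 to compound 4 (beyond the scatter).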

Compound 4, partition coefficient: 2.27
Beside the measured number, compound 4's estimate is 0.22 log units below it; the measured number falls inside the stated range.
By their numbers in this assay, from the lowest: compounds 2 and 1 (each within the scatter of the next); then compound 3; then compound 4.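

In this assay the (4-hydroxypentyl)oxy group on this aromatic carbon gives the largest steps in the series (a number 1.00 log units higher from compound 1 to compound 4 (beyond the scatter); a number 1.14 log units higher from compound 2 to compound 4 (beyond the scatter)). The number also rises further along the ether-linked chains, from 3-hydroxybutoxy to (4-hydroxypentyl)oxy (a number 0.56 log units higher from compound 3 to compound 4 (beyond the scatter)). Nothing at hand bears on the reason for these steps.

The compounds shown leave open whether a longer chain would raise the number further, and how a terminal amine or carboxylic acid would compare with the hydroxy group. They also do not separate the contribution of the ether oxygen from that of the added chain carbons.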